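A few compounds are considered here, and "the series" means these few. Any claim that something is new, unique, unknown or untested is made for them only; others in the source may bear on it.

Compound 1 `CCCCC[C@@H](C(=O)NCNC(=O)c1ccc(-c2cc(OCC)cc(C(=O)O)c2)o1)[C@@H](CC)N(O)C=O`: < 1 nM
Compound 2 `CCCCC[C@H](CN(O)C=O)C(=O)NCNC(=O)c1ccc(-c2cccc(OC)c2)o1`: 20 nM

Among the measured compounds shown here, in an assay on CHO cells for inhibition of bone morphogenetic protein 1 (Homo sapiens), with stated times of 10 min and 60 min (on this read-out lower numbers stand for stronger inhibition and higher numbers for weaker inhibition), compound 2 gives 20 nM, the only plain number among the measured compounds. Compound 1 gives < 1 nM in this assay. That reading is a limit of the assay and not a number, so compound 1 sits at the limit of < 1 nM in this assay, at which 1 of the 2 values shown sits. Compound 3 `CCCCC[C@H](CN(O)C=O)C(=O)NCNC(=O)c1ccc(-c2cccc(OCC)c2)o1` differs from compound 2 by methyl in place of hydrogen on a saturated chain carbon bound to an oxygen on an aromatic ring. For the measured compounds named here, no measured pair shows this step, so the expected change is a 1.3-fold lower number from compound 2 to compound 3 (0.12 log units; within the scatter), not beyond the usual scatter. Compound 3 is therefore estimated at 15 nM, between 5 nM and 50 nM.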

Compound 3, half-maximal inhibitory concentration: 1 nM
Compound 3: the middle estimate sits 15-fold (1.18 log units) above what was measured; measured number below the stated range.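

Going from methoxy to ethoxy on the phenyl ring matters in this assay: the added methyl gives a 20-fold lower number from compound 2 to compound 3 (1.30 log units; beyond the scatter). Among the compounds shown here, the earlier compounds offered no pair differing in one place, so this is the first sign that so small a change at this position can move the read-out this far. Compound 1 holds a limit of the assay and not a number, so further gains may not appear as plain numbers: the limit of < 1 nM in this assay, at which 1 of the 3 values shown sits.

The compounds shown leave open whether a longer chain, such as propoxy, or a branched isopropoxy group would continue this trend. They also leave open whether an amine at this position would be tolerated.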